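Acyl variation at the anilide of the shared core

The source may report more compounds than this note shows. Statements on the series, on what has been measured and on what is new or still open speak of the compounds shown alone.

Compound 1, `CCCCNC(=O)c1cc(C)c2nc(CCC)n(Cc3ccc(-c4ccccc4C(=O)O)cc3)c2c1`, gives 164 nM in an assay on isolated protein for displacement of a labelled ligand from Type-2 angiotensin II receptor (Homo sapiens), with a stated time of 180 min; a lower number here means a stronger inhibitor, a higher number a weaker inhibitor.
Compound 2, `CCCc1nc2c(C)cc(NC(=O)CC)cc2n1Cc1ccc(-c2ccccc2C(=O)O)cc1`, gives 78 nM in this assay.

Among the compounds with values here, compound 2 holds the lower of the two numbers so far; the only measured step, a 2.1-fold lower number from compound 1 to compound 2 (0.32 log units; beyond the scatter), separates it from compound 1 and is beyond the scatter, though modest.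

Compound 3, `CCCc1nc2c(C)cc(NC(=O)c3ccc(C)cc3)cc2n1Cc1ccc(-c2ccccc2C(=O)O)cc1`, differs from compound 2 by 4-methylphenyl in place of ethyl on a carbonyl carbon. Within the data shown here, the one measured step concerns a different change, the swap of butylcarbamoyl for propanoylamino, and does not test the size of the group on the carbonyl carbon of the amide. Among the measured compounds shown here, no step therefore bears directly on this change, and the expectation rests on compound 2 alone. With nothing pointing either way, the expected step of a 1.3-fold lower number from compound 2 to compound 3 (0.11 log units; within the scatter) is small, at most modest and close to the scatter. Compound 3 is accordingly estimated at 60 nM, with a range from 20 nM to 200 nM.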

Compound 3, half-maximal inhibitory concentration: > 10000 nM
Compound 3: a limit, no number (the forecaster's own chance of this, stated with the estimate: 3%); middle value at least 160-fold (2.22 log units) away from the limit.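

Compound 3 is a limit and not a number: the limit of > 10000 nM in this assay, at which 1 of the 3 values shown sits.

On this carbonyl carbon, the change from ethyl to 4-methylphenyl gives an at least 120-fold higher number from compound 2 to compound 3 (2.10 log units; beyond the scatter), and the replacement of butylcarbamoyl by ((4-methylphenyl)carbonyl)amino gives an at least 60-fold higher number from compound 1 to compound 3 (1.78 log units; beyond the scatter). Where the earlier compounds showed only a modest shift, this position in this assay now separates sharply: ethyl on the carbonyl carbon goes with compound 2 at 78 nM. With 4-methylphenyl on that carbon, compound 3 reads only as a limit.

Still open, on these data alone, is whether the loss goes with the ring or with the methyl on it; a plain phenyl, a longer chain such as pentyl, or a saturated cyclohexyl on this carbonyl carbon would separate these. As far as these compounds go, how far the true value of compound 3 lies beyond its limit also remains open.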